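This account rests on a few compounds, and the source may have more. Where it says the series, first, only, none or still open, it means among the compounds named here.

Compound 1 `CC(C)c1ccc(-c2nc(SCc3cn(CC(=O)NC(=O)Nc4ccccn4)nn3)nc(Nc3ccccc3Cl)c2C#N)cc1` and compound 3 `Cc1ccc(Nc2nc(SCc3cn(CC(=O)NC(=O)Nc4ccccn4)nn3)nc(-c3ccc(Cl)cc3)c2C#N)cc1` rest on related cores; how the two cores differ is not broken down here. In a functional assay on ECa-109 cells (Homo sapiens) for inhibition, read by MTT assay, with a stated time of 72 h (on this read-out lower numbers stand for stronger inhibition and higher numbers for weaker inhibition), compound 1 gives 23400 nM. In this assay compound 3 gives 13100 nM, and the two numbers lie within the scatter of each other. Compound 2 `CC(C)c1ccc(-c2nc(SCc3cn(CC(=O)NC(=O)Nc4ccccn4)nn3)nc(Nc3ccccc3)c2C#N)cc1` is compound 1 with hydrogen in place of chloro on an aromatic carbon. For compound 2 this assay reports only a limit, > 64000 nM. The step of an at least 2.7-fold higher number from compound 1 to compound 2 (0.43 log units; beyond the scatter) is accordingly bounded by the limit of > 64000 nM in this assay, at which 1 of the 3 values shown sits. Compound 4 `Cc1ccc(Nc2nc(SCc3cn(CC(=O)NC(=O)Nc4ccccn4)nn3)nc(-c3ccccc3)c2C#N)cc1` carries the same kind of change relative to compound 3, namely (hydrogen in place of chloro on an aromatic carbon); here the place is para to a large group, whereas for compound 2 it is ortho to a large group, so the surroundings of the change are not identical. The expected step of a 2.7-fold higher number from compound 3 to compound 4 (0.43 log units; beyond the scatter) is estimated from the measured step of an at least 2.7-fold higher number from compound 1 to compound 2 (0.43 log units; beyond the scatter), which is at least modest, allowing that the change of place may alter the size. Compound 4 is therefore expected near 35000 nM, with a range estimated from 15000 nM to 90000 nM.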

Compound 4, half-maximal inhibitory concentration: 24600 nM
Compound 4: the middle estimate sits 1.4-fold (0.15 log units) above what was measured, and the stated range covers the measured number.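

The change from 4-chlorophenyl to phenyl gives a 1.9-fold higher number from compound 3 to compound 4 (0.27 log units; within the scatter) in this assay, so on this core the step cannot be told apart from repeat-measurement scatter. Set beside the step on the other core, this result neither confirms that the change carries across cores nor shows that its size depends on the core: the same change on two cores in this assay, an at least 2.7-fold higher number (0.43 log units; beyond the scatter) from compound 1 to compound 2 and a 1.9-fold higher number (0.27 log units; within the scatter) from compound 3 to compound 4; the limit leaves it open whether they differ Compound 2 stands at a limit of the assay, so the earlier step has no fixed size, and the two pairs also differ in where the change sits on the aromatic ring: the limit of > 64000 nM in this assay, at which 1 of the 4 values shown sits.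

Open, from the compounds shown here alone, is whether a group other than chloro or hydrogen in this place, such as fluoro, methoxy, an amine or a carboxylic acid, would give a step clearly beyond the scatter. Also open, going by these compounds, is how the same change behaves when only its place varies on a single core, with the rest of the molecule held constant.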